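The source may hold more compounds than are shown below. What is called first, only, known or untested is meant among the compounds shown, and "the series" means these compounds.

In a functional assay on K562 cells (Homo sapiens) for antiproliferative activity (a higher number here means a weaker inhibitor, a lower number a stronger inhibitor), compound 1 (`CCC(=O)N[C@@H]1[C@H]2OC(C)(C)O[C@H]2O[C@@H]1[C@H](O)CO`) gives 30000000 nM, compound 2 (`CCCC(=O)N[C@@H]1[C@H]2OC(C)(C)O[C@H]2O[C@@H]1[C@H](O)CO`) gives 500000 nM and compound 3 (`CCCCC(=O)N[C@@H]1[C@H]2OC(C)(C)O[C@H]2O[C@@H]1[C@H](O)CO`) gives 5000000 nM, the second highest of the three numbers. Compound 4 (`CC(C)CC(=O)N[C@@H]1[C@H]2OC(C)(C)O[C@H]2O[C@@H]1[C@H](O)CO`) has isopropyl in place of propyl on a saturated chain carbon bound to a carbonyl carbon. For the measured compounds named here, no measured step covers this exchange. The closest evidence is chain extension, with a 60-fold lower number from compound 1 to compound 2 (1.78 log units; beyond the scatter), then a 10-fold higher number from compound 2 to compound 3 (1.00 log units; beyond the scatter), leaving a 6.0-fold lower number from compound 1 to compound 3 (0.78 log units; beyond the scatter). These steps run in opposite directions, so only weak support exists for a small expected move in this assay towards a lower number. The expected change is a 2.5-fold lower number from compound 3 to compound 4 (0.40 log units; beyond the scatter). For compound 4 the estimate is 2000000 nM, with an expected range of 300000 nM to 15000000 nM.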

Compound 4, half-maximal inhibitory concentration: 5000000 nM
Compound 4: the middle estimate sits 2.5-fold (0.40 log units) below what was measured; the range from low to high includes it.
By their numbers in this assay, from the lowest: compound 2; then compounds 3 and 4 (each within the scatter of the next); then compound 1.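

In this assay, isopropyl in place of propyl on a saturated chain carbon bound to a carbonyl carbon shows no change at the digits printed from compound 3 to compound 4 (within the scatter), so at this position the isomeric chains are not told apart. The branched chain also stays off the lowest number in the series, with a 10-fold higher number from compound 2 to compound 4 (1.00 log units; beyond the scatter), while it shares the distance from the shortest chain, with a 6.0-fold lower number from compound 1 to compound 4 (0.78 log units; beyond the scatter). No measurement bears on why these steps take this form.

From the compounds shown here alone, whether a longer chain, a cyclopropyl group or an amine on this carbon would move the number remains open.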